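The source may hold more compounds than are shown below. What is called first, only, known or untested is meant among the compounds shown, and "the series" means these compounds.

In an ADME assay on HeLa cells (Homo sapiens) for cytotoxicity, read by microscopy (on this read-out higher numbers stand for lower toxicity in this test and lower numbers for higher toxicity in this test), compound 1 `CSc1nc(NCCCCNc2ccnc3cc(Cl)ccc23)c(C#N)c(-c2ccccc2)n1` gives 100000 nM. For compound 2 `CSc1nc(-c2ccccc2)c(C#N)c(N2CCN(c3ccnc4cc(Cl)ccc34)CC2)n1` the result in this assay is only a limit of the assay, > 100000 nM, and this is the case covered by the limit of > 100000 nM in this assay, at which 1 of the 3 values shown sits. Compound 3 `CSc1nc(NCCCCNc2ccnc3cc(Cl)ccc23)c(C#N)c(-c2cccc([N+](=O)[O-])c2)n1` gives 100000 nM in this assay, level with compound 1, the step of no change at the digits printed from compound 1 to compound 3 (within the scatter) lying within the scatter. Compound 4 `CSc1nc(NCCCCNc2ccnc3cc(Cl)ccc23)c(C#N)c(-c2ccc([N+](=O)[O-])cc2)n1` is not yet measured; it differs from compound 3 by 4-nitrophenyl in place of 3-nitrophenyl on an aromatic carbon. Among the measured compounds shown here, the only measured step that bears on it, no change at the digits printed from compound 1 to compound 3 (within the scatter), showed no change beyond the scatter, so the step of no change at the digits printed from compound 3 to compound 4 (within the scatter) is expected to be none beyond the scatter. Compound 4 is therefore estimated at 100000 nM in this assay, with a range from 50000 nM to 200000 nM.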

Compound 4, minimum cytotoxic concentration: 4000 nM
Compound 4: middle estimate off by 25-fold (1.40 log units), on the high side, and the stated range ends above it.
By their numbers in this assay, from the lowest: compound 4; then compounds 1 and 3 (each within the scatter of the next).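

In this assay, the change from 3-nitrophenyl to 4-nitrophenyl gives a 25-fold lower number from compound 3 to compound 4 (1.40 log units; beyond the scatter), so two compounds with the same atoms, joined differently, are clearly separated. Nitro in place of hydrogen gives a 25-fold lower number from compound 1 to compound 4 (1.40 log units; beyond the scatter), although the same replacement left no change beyond the scatter in compound 3, so its result depends on where the nitro group sits. Nothing shown gives a cause for this step. From the compounds shown here alone, it remains open whether an amine or a carboxylic acid in place of that 4-nitro group would also lower the number.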